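Extending the sulfonyl aryl group to a naphthalene

A few compounds are considered here, and "the series" means these few. Any claim that something is new, unique, unknown or untested is made for them only; others in the source may bear on it.

Measured so far:
- compound 1, `COc1n[nH]c2ncc(-c3cn(-c4c(F)ccc(NS(=O)(=O)c5cccc(Cl)c5)c4F)nn3)cc12`: 1.9 nM
- compound 2, `COc1n[nH]c2ncc(-c3cn(-c4c(F)ccc(NS(=O)(=O)c5cccc(C)c5)c4F)nn3)cc12`: 4.4 nM

Compound 2 gives 4.4 nM in an assay on Sf9 cells for inhibition of mitogen-activated protein kinase kinase kinase 20 (Homo sapiens), read by ADP-Glo, with a stated time of 30 min (on this read-out lower numbers stand for stronger inhibition and higher numbers for weaker inhibition), the higher of the two numbers shown; compound 1 gives 1.9 nM, and the change a 2.3-fold higher number from compound 1 to compound 2 (0.36 log units; beyond the scatter) is modest. Compound 3, `COc1n[nH]c2ncc(-c3cn(-c4c(F)ccc(NS(=O)(=O)c5ccc6ccccc6c5)c4F)nn3)cc12`, carries naphthalen-2-yl in place of 3-methylphenyl on a sulfonyl sulfur. For the measured compounds named here, no measured step swaps one ring for two, so the only known step, a 2.3-fold higher number from compound 1 to compound 2 (0.36 log units; beyond the scatter), offers no direct guide. With nothing pointing either way, compound 3 is expected to stay near compound 2, a step of a 1.0-fold higher number from compound 2 to compound 3 (0.01 log units; within the scatter), giving an estimated 4.5 nM with a range from 1.5 nM to 14 nM.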

Compound 3, half-maximal inhibitory concentration: 4.5 nM
For compound 3 middle estimate and measured number coincide at the digits printed; the range from low to high includes it.
By their numbers in this assay, from the lowest: compound 1; then compounds 2 and 3 (each within the scatter of the next).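

In this assay, the sulfonyl sulfur accepts the larger naphthalen-2-yl, with its 2 six-membered aromatic rings, in place of 3-methylphenyl with no real change: a 1.0-fold higher number from compound 2 to compound 3 (0.01 log units; within the scatter). Set against 3-chlorophenyl, the same group gives a 2.4-fold higher number from compound 1 to compound 3 (0.37 log units; beyond the scatter), so compound 1 keeps the lowest number of the three. No measurement shown here accounts for these numbers.

Still open, from the compounds shown here alone, is whether naphthalen-1-yl would behave like naphthalen-2-yl. Also open, going by these compounds, is how a pyridine ring, or a phenyl ring carrying an amine or a carboxylic acid, would fare at this sulfur.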